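This account rests on a few compounds, and the source may have more. Where it says the series, first, only, none or still open, it means among the compounds named here.

For the measured compounds named here, in a functional assay on MCF7 cells (Homo sapiens) for antiproliferative activity (a higher number here means a weaker inhibitor, a lower number a stronger inhibitor), two compounds with the same core have numbers so far: compound 1 `CC(C)=CCc1cc(C(=O)Nc2cc3ccc(OCC4CCCNC4)c(C)c3oc2=O)ccc1O` gives 790 nM and compound 2 `CC(C)=CCc1cc(C(=O)Nc2cc3ccc(OCCCNC(C)C)c(C)c3oc2=O)ccc1O` gives 740 nM. Compound 2 therefore stands level with compound 1, since the step of a 1.1-fold lower number from compound 1 to compound 2 (0.03 log units; within the scatter) does not separate them. Compound 3 `CC(C)=CCc1cc(C(=O)Nc2cc3ccc(OCCCN(C)C(C)C)c(C)c3oc2=O)ccc1O` differs from compound 2 in one place: methyl in place of hydrogen on an amine nitrogen. In other words, isopropylamino becomes isopropyl(methyl)amino. Going by the values given here, no measured step makes this exact change, and the data hold no other example of substitution on this nitrogen. Among the compounds with values here, the only step that bears on it, a 1.1-fold lower number from compound 1 to compound 2 (0.03 log units; within the scatter), also concerns the amine-bearing group and stayed within the scatter. It is indirect evidence, but it gives no ground for expecting a large move in either direction. No change beyond the scatter is therefore expected in this assay, and no direction is favoured. The expected step is a 1.1-fold higher number from compound 2 to compound 3 (0.03 log units; within the scatter). For compound 3 the estimated value is 800 nM, within an expected range of 350 nM to 1800 nM.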

Compound 3, half-maximal inhibitory concentration: 1050 nM
Estimate against measurement, compound 3: 1.3-fold (0.12 log units) below; measured number inside the range.
By their numbers in this assay, from the lowest: compounds 2, 1 and 3 (each within the scatter of the next).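

In this assay, methyl in place of hydrogen on the amine nitrogen, which turns isopropylamino into isopropyl(methyl)amino, gives a 1.4-fold higher number from compound 2 to compound 3 (0.15 log units; within the scatter). For the compounds shown here, this is the first direct reading at this nitrogen, and it shows that the hydrogen there can be replaced by methyl without a step beyond the scatter. The wider exchange of 2-(isopropyl(methyl)amino)ethyl for piperidin-3-yl reads a 1.3-fold higher number from compound 1 to compound 3 (0.12 log units; within the scatter), so all three amine-bearing groups shown stand level in this assay, whether the nitrogen carries a hydrogen or a methyl, and whether it sits in a chain or in a ring; no measurement at hand accounts for this level response.

The compounds shown leave open whether the level response holds for larger groups on this nitrogen, such as ethyl or benzyl, or for a ring amine such as morpholine or pyrrolidine. They also leave open what a longer chain between the oxygen and the nitrogen would give, or a hydroxyl group in place of the amine.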